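A few compounds are considered here, and "the series" means these few. Any claim that something is new, unique, unknown or untested is made for them only; others in the source may bear on it.

For the measured compounds named here, compound 2 `CN(C)c1ncnc2[nH]cc(-c3cccc(Cl)c3)c12` holds the highest of the two numbers so far in an assay for inhibition of serine/threonine-protein kinase 3 (Homo sapiens), read by luminescence and ADP-Glo, in the presence of a further agent that is not named here (on this read-out higher numbers stand for weaker inhibition and lower numbers for stronger inhibition), where compound 2 gives 349 nM and compound 1 `OC1CCN(c2ncnc3[nH]cc(-c4cccc(Cl)c4)c23)CC1` gives 127 nM; that gap is the step of a 2.7-fold higher number from compound 1 to compound 2 (0.44 log units; beyond the scatter). Compound 3 `CC(CO)CN(C)c1ncnc2[nH]cc(-c3cccc(Cl)c3)c12` differs from compound 2 by 1-(hydroxymethyl)ethyl in place of hydrogen on a saturated chain carbon bound to a nitrogen on an aromatic ring. Going by the values given here, no measured step matches this change; the only known step, in which a hydroxyl-carrying ring gave the lower number, is a loose parallel at best, so little beyond the scatter is expected. Compound 3 is therefore estimated at 250 nM, within 100 nM to 600 nM. That amounts to an expected step of a 1.4-fold lower number from compound 2 to compound 3 (0.14 log units; within the scatter).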

Compound 3, half-maximal inhibitory concentration: 58 nM
Compound 3: middle estimate off by 4.3-fold (0.63 log units), on the high side; the measured number lies below the stated range.
By their numbers in this assay, from the lowest: compound 3; then compound 1; then compound 2.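

In this assay, the step of a 6.0-fold lower number from compound 2 to compound 3 (0.78 log units; beyond the scatter) shows that this saturated chain carbon accepts 1-(hydroxymethyl)ethyl in place of hydrogen, and that the number falls well beyond the scatter. The open chain also beats the ring: the step of a 2.2-fold lower number from compound 1 to compound 3 (0.34 log units; beyond the scatter) compares two groups of 7 heavy atoms, so among these compounds a six-membered ring is not needed for the lower number. No evidence here explains either step. As far as these compounds go, whether the hydroxyl matters stays open, and a plain 2-methylpropyl group or an amine in its place would test that.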